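Branching the Side Chain of a Propiolate Enol Ether

The source may hold more compounds than are shown below. What is called first, only, known or untested is meant among the compounds shown, and "the series" means these compounds.

Compound 1 `CCCCC(C#CC(=O)OC)O/C=C/C(=O)OC` is the strongest of three compounds measured in a functional assay on HBL-100 cells (Homo sapiens) for antiproliferative activity, read by sulforhodamine B assay, with a stated time of 48 h (on this read-out higher numbers stand for weaker inhibition of growth and lower numbers for stronger inhibition of growth), where compound 1 gives 250 nM. Compound 2 `CCOC(=O)C#CC(O/C=C/C(=O)OCC)C(C)C` gives 3000 nM and compound 3 `COC(=O)C#CC(C[C@@H](C)CCC=C(C)C)O/C=C/C(=O)OC` gives 3100 nM, both beyond the scatter from compound 1. Compound 4 `CCC(C)C(C#CC(=O)OC)O/C=C/C(=O)OC` has not yet been measured in this assay. It differs from compound 1 by one change: sec-butyl in place of butyl on a saturated chain carbon bound to an oxygen on an unsaturated carbon and a triple-bonded carbon. Going by the values given here, no single-change step between measured compounds is available, so the expectation rests on the whole set. The number for compound 4 is expected to be higher than that of compound 1, by a step of a 4.0-fold higher number from compound 1 to compound 4 (0.60 log units; beyond the scatter), because compound 2 gives 3000 nM and compound 3 gives 3100 nM. For compound 4 the estimate is 1000 nM, within a range from 300 nM to 3500 nM.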

Compound 4, concentration for 50% growth inhibition: 340 nM
For compound 4 the middle estimate is 2.9-fold (0.47 log units) above the measured one; low and high end bracket the measured number.
By their numbers in this assay, from the lowest: compounds 1 and 4 (each within the scatter of the next); then compounds 2 and 3 (each within the scatter of the next).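

At this position, on a saturated chain carbon bound to an oxygen on an unsaturated carbon and a triple-bonded carbon, sec-butyl in place of butyl gives a 1.4-fold higher number from compound 1 to compound 4 (0.13 log units; within the scatter) in this assay. Going by these compounds alone, this is the first single-change comparison in the set, and it shows that this branched chain and the straight butyl chain, each with the same carbon count, cannot be told apart in this test. Nothing available explains this result. From the compounds shown here alone, whether a tert-butyl or a phenyl group at this carbon would fall within the same range remains open.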